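The source may report more compounds than this note shows. Statements on the series, on what has been measured and on what is new or still open speak of the compounds shown alone.

Compound 1 `CCOC(=O)C12C(=O)OCC=C1COC2c1ccccc1F` carries a 2-fluorophenyl group on the shared core. In a functional assay on A549 cells (Homo sapiens) for cytotoxicity, read by MTT assay (a lower number here means a stronger inhibitor, a higher number a weaker inhibitor), compound 1 gives only a limit, > 1000000 nM. Compound 2 `CCOC(=O)C12C(=O)OCC=C1COC2c1cc(OC)cc(OC)c1` likewise gives a limit in this assay, > 1000000 nM. Compound 3 `CCOC(=O)C12C(=O)OCC=C1COC2c1ccc(N(C)C)cc1` gives a numerical value in this assay, 89600 nM. Compound 1 therefore stands where most of the series stands: the limit of > 1000000 nM in this assay, at which 2 of the 3 values shown sit. Within the data shown here, no two measured compounds differ in one place, so no measured step is available. Compound 4 `CCOC(=O)C12C(=O)OCC=C1COC2c1cccs1` is not yet measured in this assay; it differs from compound 1 in one respect: thiophen-2-yl in place of 2-fluorophenyl on a saturated ring carbon. With two of three measured compounds at the limit and only compound 3 giving a number, no basis exists for expecting a shift beyond the scatter, and a further limit is the more likely outcome. Compound 4 is expected to give in this assay about 700000 nM, in the range 100000 nM to 3000000 nM. The step from compound 1 to compound 4 that this estimate means is an at least 1.4-fold lower number from compound 1 to compound 4 (0.15 log units; that floor lies within the scatter), expected to stay within the scatter or to remain unresolved at the limit.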

Compound 4, half-maximal inhibitory concentration: > 1000000 nM
Compound 4: a limit, no number; the forecaster's own chance of this, stated with the estimate: 65%; at least 1.4-fold (0.15 log units) between middle value and limit.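

Compound 1 and compound 4 both give only limits in this assay, and the step between them cannot be read. The compounds shown leave open how thiophen-2-yl and 2-fluorophenyl compare on the shared core, with most of the series still at one value: the limit of > 1000000 nM in this assay, at which 3 of the 4 values shown sit.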